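The source may hold more compounds than are shown below. What is called first, only, known or untested is meant among the compounds shown, and "the series" means these compounds.

Measured values in a functional assay on cells (T-cell, Mus musculus) for inhibition; a higher number here means a weaker inhibitor, a lower number a stronger inhibitor:

compound 1 `O=C(/C=C/c1ccccc1)Nc1ccc2c(c1)COC2=O` gives 7240 nM
compound 2 `N#Cc1ccc(/C=C/C(=O)Nc2ccc3c(c2)COC3=O)cc1` gives 43100 nM
compound 3 `CC(=O)Oc1cccc(/C=C/C(=O)Nc2ccc3c(c2)COC3=O)c1` gives 30 nM

Compound 2 has the highest number of the three in this assay; its nearest neighbour is compound 1, and compound 3 sits furthest from it. The step to compound 4 `CC(C)(C)c1ccc(/C=C/C(=O)Nc2ccc3c(c2)COC3=O)cc1` is tert-butyl in place of cyano on an aromatic carbon.

Going by the values given here, two measured steps bear on this. Adding the cyano gave a 6.0-fold higher number from compound 1 to compound 2 (0.77 log units; beyond the scatter), so taking it away should roughly give back the number of compound 1. Placing acetoxy on the same ring gave a 240-fold lower number from compound 1 to compound 3 (2.38 log units; beyond the scatter), but at a different position and with a different group, so it tells little about tert-butyl. Among the compounds with values here, no measured compound carries tert-butyl, and no step shows what a group at this place other than cyano does; the expectation therefore rests mainly on reversing the step from compound 1 to compound 2, with wide uncertainty.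

Compound 4 is thus expected at 5000 nM, within 800 nM to 30000 nM, the step being an 8.6-fold lower number from compound 2 to compound 4 (0.94 log units; beyond the scatter).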

Compound 4, half-maximal inhibitory concentration: 720 nM
The estimate for compound 4 lay 6.9-fold (0.84 log units) above the measured number; the measured number lies below the stated range.
By their numbers in this assay, from the lowest: compound 3; then compound 4; then compound 1; then compound 2.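

Working from this assay, the place para to a large group can move the number in either direction: tert-butyl lowers it relative to hydrogen (a 10-fold lower number from compound 1 to compound 4 (1.00 log units; beyond the scatter)), whereas cyano raises it (a 6.0-fold higher number from compound 1 to compound 2 (0.77 log units; beyond the scatter)). Exchanging one group for the other therefore spans a much wider range (a 60-fold lower number from compound 2 to compound 4 (1.78 log units; beyond the scatter)), so a substituent at this place does not by itself weaken inhibition, and across these three compounds the outcome depends on the group present. Nothing measured here accounts for this difference between cyano and tert-butyl.

Still open, on these data alone, is where a methyl, a methoxy or an amine at this place would fall relative to tert-butyl and cyano. Also open, as far as these compounds go, is how the acetoxy group of compound 3 would behave at the place occupied by tert-butyl in compound 4.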